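Swapping the para substituent on the aryl group of compound 1

This account rests on a few compounds, and the source may have more. Where it says the series, first, only, none or still open, it means among the compounds named here.

Compound 1 `COc1ccc2cc(C(C)c3nnc4n3N=C(c3ccc(OC(F)(F)F)cc3)CS4)ccc2c1` is the weakest of the three measured compounds: in a functional assay on Huh-7 cells (Homo sapiens) for inhibition, read by sulforhodamine B assay, with a stated time of 72 h (on this read-out lower numbers stand for stronger inhibition and higher numbers for weaker inhibition), compound 1 gives 16000 nM, while compound 2 `CC(C)Cc1ccc(C(C)c2nnc3n2N=C(c2ccc(Cl)cc2Cl)CS3)cc1` gives 7500 nM and compound 3 `CC(C)Cc1ccc(C(C)c2nnc3n2N=C(c2ccc(Br)cc2)CS3)cc1` gives 4900 nM, both beyond the scatter from compound 1. Compound 4 `COc1ccc2cc(C(C)c3nnc4n3N=C(c3ccc(C)cc3)CS4)ccc2c1` differs from compound 1 in one place: methyl in place of trifluoromethoxy on an aromatic carbon. Among the compounds with values here, the only measured step on that part of the molecule is a 1.5-fold lower number from compound 2 to compound 3 (0.18 log units; within the scatter), which exchanges one halogenated aryl group for another on a different core and therefore bears only loosely on the present change; it was small. Within the data shown here, no measured pair exchanges trifluoromethoxy for methyl. Among the measured compounds shown here, with no direct precedent, the step from compound 1 to compound 4 is expected to be small, and a 1.3-fold lower number from compound 1 to compound 4 (0.12 log units; within the scatter) is estimated to stay inside the usual scatter. Compound 4 is therefore estimated at 12000 nM in this assay, within a range from 5000 nM to 30000 nM.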

Compound 4, half-maximal inhibitory concentration: 8200 nM
Beside the measured number, compound 4's estimate is 1.5-fold (0.17 log units) above it, within the range that was stated.
By their numbers in this assay, from the lowest: compounds 3, 2, 4 and 1 (each within the scatter of the next, the first and the last beyond it).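

Within the data shown here, the exchange of 4-(trifluoromethoxy)phenyl for 4-methylphenyl gives the first direct reading at this place on the shared core: in this assay it is a 2.0-fold lower number from compound 1 to compound 4 (0.29 log units; within the scatter). Five heavy atoms and the one hydrogen-bond acceptor of trifluoromethoxy give way to the single carbon of methyl, yet the two compounds stay within the scatter of each other, so this assay does not separate these two groups. Nothing available accounts for this outcome.

The compounds shown leave open whether an amine or a carboxylic acid on this aromatic carbon would also stay within the scatter of compound 4. They also leave open how the 4-bromophenyl group of compound 3 would read on the core of compound 1.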